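The source may hold more compounds than are shown below. What is called first, only, known or untested is meant among the compounds shown, and "the series" means these compounds.

Working notes on the series.

Compound 1 `N#Cc1cccc(-c2nc(N)c3nc(-c4ccccc4)sc3n2)c1` carries a cyano group on the phenyl ring attached to the core; in an assay on CHO cells for displacement of a labelled ligand from adenosine receptor A3 (Homo sapiens), read by scintillation counting, with a stated time of 3 h (a higher number here means a weaker inhibitor, a lower number a stronger inhibitor), compound 1 gives 247 nM. Compound 2 `Nc1nc(-c2cccc(O)c2)nc2sc(-c3ccccc3)nc12` differs from compound 1 by hydroxy in place of cyano on an aromatic carbon, and in this assay compound 2 gives 190 nM. The step of a 1.3-fold lower number from compound 1 to compound 2 (0.11 log units; within the scatter) is small and falls within the scatter, so the two values cannot be ordered.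

Compound 3 `N#Cc1cccc(-c2nc(N)c3nc(-c4ccco4)sc3n2)c1` keeps the cyano group of compound 1 but differs in the core by furan-2-yl in place of phenyl on an aromatic carbon. In this assay compound 3 gives 61.5 nM, and the step of a 4.0-fold lower number from compound 1 to compound 3 (0.60 log units; beyond the scatter) is beyond the scatter. Among the three measured compounds, compound 3 holds the lowest number, and its gaps to compound 2 and to compound 1 are both beyond the scatter.

Compound 4 `Nc1nc(-c2cccc(O)c2)nc2sc(-c3ccco3)nc12` is not yet measured. It differs from compound 3 by hydroxy in place of cyano on an aromatic carbon, the same change that was made from compound 1 to compound 2, now on the furan-bearing core of compound 3. The place is the same in both pairs. Within the data shown here, since the only example of this change, the step of a 1.3-fold lower number from compound 1 to compound 2 (0.11 log units; within the scatter), lies within the scatter, the change is expected to move the number little. For compound 4 in this assay a value of 50 nM is expected, with a range from 20 nM to 130 nM. This expectation rests on compound 3 at 61.5 nM and on the near-flat step a 1.3-fold lower number from compound 1 to compound 2 (0.11 log units; within the scatter). The expected step is then a 1.2-fold lower number from compound 3 to compound 4 (0.09 log units; within the scatter).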

Compound 4, inhibition constant: 15.7 nM
Compound 4: middle estimate off by 3.2-fold (0.50 log units), on the high side; the whole stated range lies above it.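

On the furan-bearing core of compound 3, hydroxy in place of cyano gives a 3.9-fold lower number from compound 3 to compound 4 (0.59 log units; beyond the scatter) in this assay, and this step does not match the earlier one on the core of compound 1: the same change on two cores in this assay, a 1.3-fold lower number (0.11 log units; within the scatter) from compound 1 to compound 2 and a 3.9-fold lower number (0.59 log units; beyond the scatter) from compound 3 to compound 4, 3.0-fold (0.48 log units) apart, beyond the scatter of two such steps

Read the other way, furan-2-yl in place of phenyl gives a 12-fold lower number from compound 2 to compound 4 (1.08 log units; beyond the scatter), and the size of this step also differs with the group carried on the six-membered aromatic ring: the same change on two cores in this assay, a 4.0-fold lower number (0.60 log units; beyond the scatter) from compound 1 to compound 3 and a 12-fold lower number (1.08 log units; beyond the scatter) from compound 2 to compound 4, 3.0-fold (0.48 log units) apart, beyond the scatter of two such steps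

These four compounds therefore show that the size of a step cannot be carried unchanged from one core to another in this series, but as a single set of matched pairs they do not show how either change would behave on a further core, and they give no reason for the difference.

Open, on these data alone, is whether the larger step seen with hydroxy on the furan-bearing core would also appear with an amine or a methoxy group on the same aromatic carbon. Also open, as far as these compounds go, is whether another ring in place of furan-2-yl, such as thiophen-2-yl, would depend in the same way on the group carried by the six-membered aromatic ring.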